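Replacing the aminophenyl arm with a dichlorophenyl arm

The source may report more compounds than this note shows. Statements on the series, on what has been measured and on what is new or still open speak of the compounds shown alone.

Measured compounds:
Compound 1, `COc1cc(-c2cc(/C=C/C(=O)c3ccc(N)cc3)[nH]n2)cc(OC)c1OC`, 1770 nM
Compound 2, `COc1ccc(-c2cc(/C=C/C(=O)c3ccc(OC)c(OC)c3)[nH]n2)cc1`, 2350 nM

The two measured compounds share a core built around a chalcone-like chain linked to a pyrazole. In a functional assay on HOP-62 cells (Homo sapiens) for inhibition, read by sulforhodamine B assay, with a stated time of 48 h (on this read-out higher numbers stand for weaker inhibition of growth and lower numbers for stronger inhibition of growth), compound 1 gives 1770 nM, the lower of the two numbers recorded so far. Compound 2 gives 2350 nM in this assay, and the gap between these two values lies within the scatter of repeated measurements, so neither compound can be called the more potent on this evidence.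

Compound 3, `COc1cc(-c2cc(/C=C/C(=O)c3ccc(Cl)c(Cl)c3)[nH]n2)cc(OC)c1OC`, has not yet been tested. It differs from compound 1 in one place: 3,4-dichlorophenyl in place of 4-aminophenyl on a carbonyl carbon. Among the compounds with values here, no pair of measured compounds shows what such a change does on this core, so there is no measured step to lean on. Given the absence of any guiding comparison, the account expects a step of a 1.1-fold higher number from compound 1 to compound 3 (0.05 log units; within the scatter) of modest size in this assay, with no confident direction beyond the scatter. Compound 3 is therefore estimated at 2000 nM in this assay, with a range from 500 nM to 8000 nM.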

Compound 3, concentration for 50% growth inhibition: 1720 nM
The estimate for compound 3 lay 1.2-fold (0.07 log units) above the measured number; the range from low to high includes it.
By their numbers in this assay, from the lowest: compounds 3, 1 and 2 (each within the scatter of the next).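

In this assay, within the data shown here, putting 3,4-dichlorophenyl in place of 4-aminophenyl on the carbonyl carbon gives a 1.0-fold lower number from compound 1 to compound 3 (0.01 log units; within the scatter), the first measured step at this position on the shared core. The arm that leaves carries a hydrogen-bond donor and a hydrogen-bond acceptor and the arm that enters carries neither, yet this single pair shows no readable change in growth inhibition, even though the exchange also swaps nitrogen for chlorine and alters the heavy-atom count of the arm. Nothing measured on these compounds accounts for why the two arms read alike.

One step on one core cannot show whether this position is generally indifferent to what it carries or whether these two arms merely happen to coincide, and a phenyl arm bearing a single chlorine, a nitrile or a carboxylic acid would help separate those readings. On these data alone, it also remains open whether the same exchange would give a similar result on a core with a different group in place of the trimethoxyphenyl arm.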